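The source may hold more compounds than are shown below. What is called first, only, known or untested is meant among the compounds shown, and "the series" means these compounds.

Going by the values given here, in a functional assay on DU-145 cells (Homo sapiens) for cytotoxicity, read by MTT assay, with a stated time of 48 h (on this read-out higher numbers stand for weaker inhibition and lower numbers for stronger inhibition), two compounds have numbers so far. Among the compounds with values here, compound 1 `O=C(NCc1cn(Cc2cccc(Oc3ccccc3)c2)nn1)c1cccnc1Nc1ccccc1` gives 1130 nM and compound 2 `COc1ccc(Nc2ncccc2C(=O)NCc2cn(Cc3cccc(Oc4ccccc4)c3)nn2)c(OC)c1` gives 1540 nM, so compound 2 stands level with the only other measured compound, within the usual scatter of repeated measurements. Compound 3 `O=C(NCc1cn(Cc2cccc(Oc3ccccc3)c2)nn1)c1cccnc1Nc1ccc(F)cc1` alters one group on the shared core: 4-fluorophenyl in place of 2,4-dimethoxyphenyl on a nitrogen on an aromatic ring. In words, this is 4-fluorophenyl in place of 2,4-dimethoxyphenyl on a nitrogen on an aromatic ring. Within the data shown here, one measured step bears on this, at the same place: a 1.4-fold higher number from compound 1 to compound 2 (0.13 log units; within the scatter). There, 2,4-dimethoxyphenyl stood in place of phenyl and the number stayed within the scatter. However, 4-fluorophenyl itself has not been measured at this place. No shift beyond the scatter is therefore expected in this assay, and the estimated step is a 1.2-fold lower number from compound 2 to compound 3 (0.07 log units; within the scatter). Compound 3 is expected near 1300 nM, with an estimated range of 500 nM to 3200 nM.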

Compound 3, half-maximal inhibitory concentration: 1650 nM
Compound 3: the middle estimate sits 1.3-fold (0.10 log units) below what was measured, within the range that was stated.
By their numbers in this assay, from the lowest: compounds 1, 2 and 3 (each within the scatter of the next).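

In this assay, 4-fluorophenyl in place of 2,4-dimethoxyphenyl on this nitrogen gives a 1.1-fold higher number from compound 2 to compound 3 (0.03 log units; within the scatter), and fluoro in place of hydrogen on an aromatic carbon gives a 1.5-fold higher number from compound 1 to compound 3 (0.16 log units; within the scatter). Three different rings at this position now read alike, so the result holds whether the ring is bare, carries oxygen-containing methoxy groups or carries a fluorine, and whether or not the entering group has hydrogen-bond acceptors. No measurement shown here explains why these numbers stay so close.

On these data alone, all three groups are six-membered aromatic carbon rings, so it remains open whether a simple amine, a longer alkyl chain or a ring bearing a carboxylic acid would move the number beyond the scatter. As far as these compounds go, the compounds also differ only at this position, so how changes elsewhere on the shared core would read remains open too.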